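This account rests on a few compounds, and the source may have more. Where it says the series, first, only, none or still open, it means among the compounds named here.

Three compounds have been measured in a functional assay on CHO cells for antagonist activity at prostaglandin E2 receptor EP4 subtype (Homo sapiens), read by calcium flux, with a stated time of 15 min; a lower number here means a stronger inhibitor, a higher number a weaker inhibitor:

Compound 1 `C[C@H](NC(=O)c1c(-c2ccccc2)nnn1Cc1ccc(F)cc1)c1ccc(C(=O)O)cc1` gives 330 nM in this assay.
Compound 2 `C[C@H](NC(=O)c1c(-c2ccccc2)nnn1Cc1ccc(F)c(F)c1)c1ccc(C(=O)O)cc1` gives 148 nM in this assay.
Compound 3 `COc1ccc(Cn2nnc(-c3ccccc3)c2C(=O)N[C@@H](C)c2ccc(C(=O)O)cc2)cc1` gives 9.3 nM in this assay.

Compound 3 has the lowest number of the three, beyond the scatter against both others: compound 2 sits a 16-fold lower number from compound 2 to compound 3 (1.20 log units; beyond the scatter), and compound 1 sits a 35-fold lower number from compound 1 to compound 3 (1.55 log units; beyond the scatter). The step of a 2.2-fold lower number from compound 1 to compound 2 (0.35 log units; beyond the scatter) shows that a fluoro in place of hydrogen on the benzyl ring changes the number only modestly.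

Compound 4 `COc1cccc(Cn2nnc(-c3ccccc3)c2C(=O)N[C@@H](C)c2ccc(C(=O)O)cc2)c1` differs from compound 3 by 3-methoxyphenyl in place of 4-methoxyphenyl on a saturated chain carbon bound to an aromatic nitrogen. Among the measured compounds shown here, no measured step moves a group from one ring position to another; the measured steps only show that the methoxy group in compound 3 goes with a much lower number than the fluoro in compound 1, and that a change on this ring can be small or large. A positional move of the same group is expected to cost something in this assay, but less than the gain seen from compound 1 to compound 3. Compound 4 is therefore estimated at 25 nM, in the range 7 nM to 100 nM, which means an expected step of a 2.7-fold higher number from compound 3 to compound 4 (0.43 log units; beyond the scatter).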

Compound 4, half-maximal inhibitory concentration: 96.8 nM
Beside the measured number, compound 4's estimate is 3.9-fold (0.59 log units) below it; the range from low to high includes it.
By their numbers in this assay, from the lowest: compound 3; then compounds 4 and 2 (each within the scatter of the next); then compound 1.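

In this assay, moving the methoxy group alone, with the same atoms joined differently, gives a 10-fold higher number from compound 3 to compound 4 (1.02 log units; beyond the scatter), so among these compounds the low number of compound 3 goes with 4-methoxyphenyl and not simply with having a methoxy group on this ring. With 3-methoxyphenyl at this place, the number can no longer be told apart from the one with 3,4-difluorophenyl, as a 1.5-fold lower number from compound 2 to compound 4 (0.18 log units; within the scatter) shows, while a smaller gap remains to the one with 4-fluorophenyl, seen in a 3.4-fold lower number from compound 1 to compound 4 (0.53 log units; beyond the scatter). The position of one group on this ring therefore matters about as much here as the change from fluoro to methoxy, but no outside measurement bears on why this is so.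

The compounds shown leave open whether an ethoxy, a hydroxyl or a chloro group in place of the methoxy group of compound 3 would keep its low number. They also leave open what a second methoxy group on this ring would do, and whether the effect of moving the group holds when the phenyl on the core is replaced by a pyridine.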